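Swapping one hydroxy for diethylamino on compound 2

The source may report more compounds than this note shows. Statements on the series, on what has been measured and on what is new or still open speak of the compounds shown alone.

In a functional assay on HepG2 cells (Homo sapiens) for cytotoxicity, read by MTT assay, with a stated time of 72 h (on this read-out lower numbers stand for stronger inhibition and higher numbers for weaker inhibition), so far
Compound 1 `O=C(N/N=C/c1ccc(F)cc1Cl)Nc1cc2c(Nc3ccc(F)c(Cl)c3)ncnc2cc1O[C@H]1CCOC1` gives 26100 nM
Compound 2 `O=C(N/N=C/c1ccc(O)cc1O)Nc1cc2c(Nc3ccc(F)c(Cl)c3)ncnc2cc1O[C@H]1CCOC1` gives 4530 nM

Compound 2 holds the lower of the two numbers. Compound 3 `CCN(CC)c1ccc(/C=N/NC(=O)Nc2cc3c(Nc4ccc(F)c(Cl)c4)ncnc3cc2O[C@H]2CCOC2)c(O)c1` differs from it in one place (diethylamino in place of hydroxy on an aromatic carbon), with diethylamino in place of hydroxy on an aromatic carbon. Among the compounds with values here, the only measured step (a 5.8-fold lower number from compound 1 to compound 2 (0.76 log units; beyond the scatter)) is modest but beyond the scatter. It replaced the whole 2-chloro-4-fluorophenyl group, so it says little about diethylamino. No step beyond the scatter is therefore expected in this assay for this change. The expected shift (a 1.2-fold higher number from compound 2 to compound 3 (0.08 log units; within the scatter)) is small. Compound 3 is estimated at 5500 nM (1800 nM to 17000 nM).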

Compound 3, half-maximal inhibitory concentration: 15700 nM
Compound 3: middle estimate off by 2.9-fold (0.46 log units), on the low side, and the stated range covers the measured number.
By their numbers in this assay, from the lowest: compound 2; then compounds 3 and 1 (each within the scatter of the next).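

In this assay, this aromatic carbon is sensitive to its group: diethylamino in place of hydroxy gives a 3.5-fold higher number from compound 2 to compound 3 (0.54 log units; beyond the scatter), which is weaker inhibition. Replacing 2-chloro-4-fluorophenyl with 4-(diethylamino)-2-hydroxyphenyl gives a 1.7-fold lower number from compound 1 to compound 3 (0.22 log units; within the scatter), so of these three compounds only compound 2, with its 2,4-dihydroxyphenyl group, stands apart. Nothing measured here explains either step. From the compounds shown here alone, it remains open whether the loss comes from removing hydroxy or from adding diethylamino, and how methoxy, dimethylamino or a plain hydrogen on this carbon would read.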